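Fluoro on the central ring of compound 1

The source may report more compounds than this note shows. Statements on the series, on what has been measured and on what is new or still open speak of the compounds shown alone.

Compound 1 `O=C(Nc1ccc(Oc2ccnc3[nH]ccc23)cc1)c1nn(-c2ccc(Cl)cc2)ccc1=O` is the starting point. Among the measured compounds shown here, in a functional assay on A549 cells (Homo sapiens) for cytotoxicity, read by MTT assay, with a stated time of 72 h (a lower number here means a stronger inhibitor, a higher number a weaker inhibitor), compound 1 gives 25100 nM, the second highest of the three numbers measured so far. Compound 2 `COc1ccc(-n2ccc(=O)c(C(=O)Nc3ccc(Oc4ccnc5[nH]ccc45)cc3)n2)cc1` gives 53100 nM, and compound 3 `O=C(Nc1ccc(Oc2ccnc3[nH]ccc23)cc1)c1nn(-c2ccccc2)ccc1=O` gives 10500 nM. The three differ only in one group on one aromatic carbon: there is a 2.1-fold higher number from compound 1 to compound 2 (0.33 log units; beyond the scatter), a 2.4-fold lower number from compound 1 to compound 3 (0.38 log units; beyond the scatter) and a 5.1-fold lower number from compound 2 to compound 3 (0.70 log units; beyond the scatter), so swapping that group moves the number only modestly in either direction.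

Compound 4 `O=C(Nc1ccc(Oc2ccnc3[nH]ccc23)c(F)c1)c1nn(-c2ccc(Cl)cc2)ccc1=O` is not yet measured. It differs from compound 1 by fluoro in place of hydrogen on an aromatic carbon, the place being ortho to a large group and meta to a large group. For the measured compounds named here, none of the measured steps touches the aromatic carbon where the fluoro enters; they all concern a different group elsewhere, and each was modest. Going by the values given here, with no direct precedent, the expectation is a step in this assay no larger than the scatter, with no preferred direction: the step from compound 1 to compound 4 is expected to be a 1.0-fold lower number from compound 1 to compound 4 (0.00 log units; within the scatter). Compound 4 is therefore estimated at 25000 nM, with a likely range from 9000 nM to 70000 nM.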

Compound 4, half-maximal inhibitory concentration: > 60000 nM
Compound 4 gave a limit, no number (the forecaster's own chance of this, stated with the estimate: 10%); middle value at least 2.4-fold (0.38 log units) away from the limit.
By their numbers in this assay, from the lowest: compound 3; then compound 1; then compound 2. At a limit, above all of these: compound 4.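

Compound 4 gives a limit and not a number in this assay: the limit of > 60000 nM in this assay, at which 1 of the 4 values shown sits. Fluoro in place of hydrogen, on an aromatic carbon ortho to a large group and meta to a large group, brings an at least 2.3-fold higher number from compound 1 to compound 4 (0.37 log units; beyond the scatter), so even one added fluorine atom at this place moves the result towards a weaker inhibitor by more than the usual scatter. Among the compounds shown here, the earlier steps all concerned one group at a different place, so they said nothing about this carbon; this step shows that it is sensitive to change, but with a limit only the direction and a minimum size can be read, and the full size of the step remains unknown.

As far as these compounds go, it remains open whether this shift belongs to fluoro itself or would follow any group at this carbon, a question that a methyl or an amine at the same place could help to settle. It is also open whether fluoro here would act in the same way on compound 3, which has hydrogen where compound 1 has chloro, and the results shown give no reason for the shift.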